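Removing One Phenyl from a Carbamate Lipase Inhibitor

The compounds below may be only part of what the source reports. "The series", "measured", "known", "first", "only" and "open" are said of these compounds alone.

Compound 1 `N#Cc1cccc(OC(=O)N2CCC(C(c3ccccc3)c3ccccc3)CC2)c1`: 36.5 nM
Compound 2 `N#Cc1cccc(OC(=O)N2CCC(C(c3ccccc3)c3ccccc3)CC2)n1`: 75.8 nM
Compound 3 `Cc1cc(C#N)cc(OC(=O)N2CCC(C(c3ccccc3)c3ccccc3)CC2)c1`: 150 nM

In an assay on isolated protein for inhibition of Monoglyceride lipase (Rattus norvegicus), read by fluorescence, with stated times of 15 min and 3 h (on this read-out lower numbers stand for stronger inhibition and higher numbers for weaker inhibition), compound 1 gives the lowest number of the three; the change to compound 2 gives a 2.1-fold higher number from compound 1 to compound 2 (0.32 log units; beyond the scatter) and the change to compound 3 gives a 4.1-fold higher number from compound 1 to compound 3 (0.61 log units; beyond the scatter). Both of those steps alter the aryl group on the oxygen next to the carbonyl, so they describe the other end of the molecule.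

Compound 4 `N#Cc1cccc(OC(=O)N2CCC(Cc3ccccc3)CC2)c1` has not been measured. It differs from compound 1 in one place: hydrogen in place of phenyl on a saturated chain carbon bound to an aromatic carbon and a saturated ring carbon. For the measured compounds named here, no measured step touches the diphenylmethyl part of compound 1, so nothing here tells directly how much of the inhibition rests on the second phenyl. Loss of a whole aromatic ring is a larger structural change than either of the measured steps, and it is expected to weaken inhibition more than they did, giving a step of an 11-fold higher number from compound 1 to compound 4 (1.04 log units; beyond the scatter) in this assay. The estimated value for compound 4 is therefore 400 nM, with a range from 100 nM to 2000 nM.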

Compound 4, half-maximal inhibitory concentration: 157 nM
Compound 4: the middle estimate sits 2.5-fold (0.41 log units) above what was measured, and the stated range covers the measured number.
By their numbers in this assay, from the lowest: compound 1; then compounds 2, 3 and 4 (each within the scatter of the next, the first and the last beyond it).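

For the compounds shown here, replacing one phenyl of compound 1 with hydrogen, on the saturated chain carbon bound to an aromatic carbon and a saturated ring carbon, gives a 4.3-fold higher number from compound 1 to compound 4 (0.63 log units; beyond the scatter) in this assay, the first measured step at this end of the molecule. The step lies beyond the scatter, so the second phenyl contributes to inhibition, but it is modest, so inhibition does not depend on that ring alone: compound 4 still gives 157 nM in this assay. No measurement here explains why removing this ring changes inhibition by this amount. From the compounds shown here alone, whether a ring is needed on this carbon remains open, since a methyl, a hydroxyl or an amine could take the place of the phenyl. It is also unknown whether a cyclohexyl could replace the phenyl and match compound 1.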